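The compounds below may be only part of what the source reports. "The series", "measured", "known", "first", "only" and "open" are said of these compounds alone.

Three compounds have been measured in a functional assay on HeLa cells (Homo sapiens) for antiproliferative activity, read by MTT assay, with a stated time of 72 h; a lower number here means a stronger inhibitor, a higher number a weaker inhibitor:

compound 1, `Nc1nc(N)c2cc(CSC(=S)N3CCN(c4ccccc4)CC3)ccc2n1`, giving 2840 nM
compound 2, `Nc1nc(N)c2cc(CSC(=S)N3CCN(c4ccccc4Cl)CC3)ccc2n1`, giving 4050 nM
compound 3, `Nc1nc(N)c2cc(CSC(=S)N3CCN(c4ccc(F)cc4)CC3)ccc2n1`, giving 1840 nM

Among these three numbers, compound 1 stands second highest. Its nearest neighbour is compound 2, reached by a 1.4-fold higher number from compound 1 to compound 2 (0.15 log units; within the scatter), and its furthest is compound 3, reached by a 1.5-fold lower number from compound 1 to compound 3 (0.19 log units; within the scatter); both of these steps fall within the scatter, so the three compounds cannot be ordered with confidence against one another. Among the measured compounds shown here, the only step that goes beyond the scatter is a 2.2-fold lower number from compound 2 to compound 3 (0.34 log units; beyond the scatter), and even that one is modest.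

The unmeasured compound 4, `CC(=O)c1ccc(N2CCN(C(=S)SCc3ccc4nc(N)nc(N)c4c3)CC2)cc1`, differs from compound 1 in one place: acetyl in place of hydrogen on an aromatic carbon. The change sits on the same six-membered ring of carbon only that carries the substituents in compound 2 and compound 3, and, like the fluoro of compound 3, it sits para to a large group. The two steps that bear on it, a 1.4-fold higher number from compound 1 to compound 2 (0.15 log units; within the scatter) and a 1.5-fold lower number from compound 1 to compound 3 (0.19 log units; within the scatter), both stayed within the scatter, so a substituent on this ring has so far moved the number little in either direction. The step from compound 1 to compound 4 is therefore expected to be a 1.1-fold lower number from compound 1 to compound 4 (0.04 log units; within the scatter), that is, no change beyond the scatter. On this basis compound 4 is estimated to give 2600 nM in this assay, most likely between 1000 nM and 6500 nM.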

Compound 4, half-maximal inhibitory concentration: 2040 nM
Beside the measured number, compound 4's estimate is 1.3-fold (0.11 log units) above it; the range from low to high includes it.
By their numbers in this assay, from the lowest: compounds 3, 4, 1 and 2 (each within the scatter of the next, the first and the last beyond it).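

In this assay, among the compounds shown here, the earlier compounds carried only a single halogen atom on this ring, whereas acetyl adds three heavy atoms, including a carbonyl, para to a large group, and the number still stays within the scatter (a 1.4-fold lower number from compound 1 to compound 4 (0.14 log units; within the scatter)). The larger group also cannot be told apart from fluoro at this place (a 1.1-fold higher number from compound 3 to compound 4 (0.04 log units; within the scatter)), and compound 4 likewise stays within the scatter of the 2-chlorophenyl compound (a 2.0-fold lower number from compound 2 to compound 4 (0.30 log units; within the scatter)), so this ring has now accepted a group of several atoms without a step beyond the scatter. Nothing available here accounts for this lack of movement.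

The compounds shown leave open whether an amine, a carboxylic acid or a longer chain at the same place would also stay within the scatter, or whether a group of one of these kinds would finally move the number clearly. They also leave open whether changes made away from this ring, in the shared core, would matter more than those made on it.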